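A few compounds are considered here, and "the series" means these few. Any claim that something is new, unique, unknown or untested is made for them only; others in the source may bear on it.

Measured so far:
Compound 1 `Cn1cncc1CN1CC(N(CC2CCN(C(=O)Nc3ccc(Br)cc3)CC2)S(=O)(=O)c2ccccn2)Cc2cc(C#N)ccc21`: 0.6 10^-6 cm/s
Compound 2 `Cn1cncc1CN1CC(N(CCn2cccc2)S(=O)(=O)c2ccccn2)Cc2cc(C#N)ccc21`: 12.4 10^-6 cm/s
Compound 3 `Cn1cncc1CN1CC(N(CC2CCN(C(=O)CC(C)(C)C)CC2)S(=O)(=O)c2ccccn2)Cc2cc(C#N)ccc21`: 0.5 10^-6 cm/s

In an ADME assay on Caco-2 cells (Homo sapiens) for permeability, in the apical to basolateral direction (on this read-out lower numbers stand for lower permeability and higher numbers for higher permeability), compound 1 stands second highest of the three numbers. Its nearest neighbour is compound 3, reached by the step of a 1.2-fold lower number from compound 1 to compound 3 (0.08 log units; within the scatter). Compound 2 lies far off, its value being the highest of the set.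

Compound 4 `CCNC(=O)N1CCC(CN(C2Cc3cc(C#N)ccc3N(Cc3cncn3C)C2)S(=O)(=O)c2ccccn2)CC1` differs from compound 1 by ethyl in place of 4-bromophenyl on an amide-type nitrogen. Going by the values given here, no measured pair shows this exact exchange. Among the compounds with values here, the one step at the same carbonyl carbon, a 1.2-fold lower number from compound 1 to compound 3 (0.08 log units; within the scatter), changed little, so an exchange on this amide-type nitrogen is not expected to move the number beyond the scatter in this assay. Compound 4 is therefore estimated at 0.8 10^-6 cm/s, within 0.3 10^-6 cm/s to 2.5 10^-6 cm/s, an expected step of a 1.3-fold higher number from compound 1 to compound 4 (0.12 log units; within the scatter).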

Compound 4, apparent permeability: 0.6 10^-6 cm/s
The estimate for compound 4 lay 1.3-fold (0.12 log units) above the measured number; measured number inside the range.
By their numbers in this assay, from the lowest: compounds 3, 1 and 4 (each within the scatter of the next); then compound 2.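

On this amide-type nitrogen, ethyl in place of 4-bromophenyl gives no change at the digits printed from compound 1 to compound 4 (within the scatter) in this assay and so shows that this aromatic ring can go without moving the number beyond the scatter. Ethylamino in place of neopentyl on the carbonyl carbon gives a 1.2-fold higher number from compound 3 to compound 4 (0.08 log units; within the scatter) and adds a second small step at this place. The large gap remains at the saturated chain carbon bound to the sulfonamide nitrogen, with a 21-fold lower number from compound 2 to compound 4 (1.32 log units; beyond the scatter) for 1-(ethylcarbamoyl)piperidin-4-yl in place of (1H-pyrrol-1-yl)methyl. Nothing shown accounts for these numbers. From the compounds shown here alone, whether a longer chain ending in an amine or a carboxylic acid on this nitrogen would stay equally close remains open.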